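Swapping Chloro for Amino on Two Related Cores

The source may hold more compounds than are shown below. What is called first, only, known or untested is meant among the compounds shown, and "the series" means these compounds.

Of the compounds shown here, three have been tested in an assay on isolated protein for inhibition of Ca2+/calmodulin-dependent protein kinase II (CaM kinase II) (Rattus norvegicus), tested at 30 uM; a higher number here means more inhibition at the concentration tested (going by the name of the read-out), a lower number less inhibition. Compound 1 `Fc1ccc(Cn2cnc3c(Cl)ncnc32)cc1` gives 0%. Compound 2 `Fc1ccc(Cn2cnc3ncnc(Cl)c32)cc1` is built from the same atoms as compound 1, joined differently; the difference between the two cores is not broken down here. In this assay compound 2 gives 8%. Compound 3 `Nc1ncnc2c1ncn2Cc1ccc(F)cc1` carries an amino group where compound 1 carries chloro, and in this assay compound 3 gives 9%.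

The change from compound 1 to compound 3 is amino in place of chloro on an aromatic carbon. It made a step of a number 9 percentage points higher from compound 1 to compound 3 (within the scatter), so the three measured numbers sit close together, with none separated from the others by more than the usual spread of repeated measurements.

Compound 4 `Nc1ncnc2ncn(Cc3ccc(F)cc3)c12` has not yet been measured. It differs from compound 2 by amino in place of chloro on an aromatic carbon. The description of the place is word for word the same as for the change from compound 1 to compound 3, so this is the same change, carried out on the core of compound 2 instead of the core of compound 1.

For compound 4 the step expected in this assay is a number 6 percentage points higher from compound 2 to compound 4 (within the scatter) because the same change earlier gave a number 9 percentage points higher from compound 1 to compound 3 (within the scatter). For the measured compounds named here, only one earlier example of the change exists, and it lay within the scatter, so the expectation is loose. Compound 4 is estimated at 14%. For compound 4 the expected range runs from 0% to 30%.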

Compound 4, a percentage reported as inhibition, at one concentration (the size of the read-out at that concentration, not a potency): 8%
Estimate against measurement, compound 4: 6 percentage points above; the range from low to high includes it.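

In this assay, the same swap of chloro for amino on the second core gives no change at the digits printed from compound 2 to compound 4 (within the scatter). Set beside the earlier case, the two steps lie within the scatter of each other: the same change on two cores in this assay, a number 9 percentage points higher (within the scatter) from compound 1 to compound 3 and no change at the digits printed (within the scatter) from compound 2 to compound 4, 9 percentage points apart, within the scatter of two such steps. For the compounds shown here, this shows only that the change behaves alike on both cores in a narrow sense, since on each it leaves the number within the usual spread of repeated measurements; it does not show that amino truly differs from chloro on either core, and with all four numbers sitting this close together, a real difference in how the two cores respond can be neither seen nor ruled out.

Still open, from the compounds shown here alone, is whether another group in the same place, such as a methylamino group, a hydroxyl or a carboxylic acid, would move the number clear of the scatter on either core. Also open is what a longer chain in place of the group that carries the fluorine would do, and how any of these compounds would fare at other concentrations, as a single-concentration reading is not a potency.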